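The source may hold more compounds than are shown below. What is called first, only, known or untested is meant among the compounds shown, and "the series" means these compounds.

The series shares one core, seen in compound 1 `CCOC(=O)Cn1c(=O)n(C2OC(CO)[C@@H](O)[C@H]2O)c2nc(N)nc(O)c21` and compound 2 `Cn1c(=O)n(C2OC(CO)[C@@H](O)[C@H]2O)c2nc(N)nc(O)c21`; the two differ only at a saturated chain carbon bound to an aromatic nitrogen. In a functional assay on the whole organism (B cells) with Mus musculus as the target (on this read-out lower numbers stand for smaller maximal responses and higher numbers for larger maximal responses), compound 1 gives 86%, and compound 2 gives 99%. Within the data shown here, the single measured step, a number 13 percentage points higher from compound 1 to compound 2 (beyond the scatter), is the only comparison available so far. Among the measured compounds shown here, compound 2 thus stands at the higher of the two numbers, with compound 1 as its only neighbour, a number beyond the scatter below it.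

Compound 3 `Nc1nc(O)c2c(n1)n(C1OC(CO)[C@@H](O)[C@H]1O)c(=O)n2CCN1CCCCC1` is not yet measured. It differs from compound 2 by (piperidin-1-yl)methyl in place of hydrogen on a saturated chain carbon bound to an aromatic nitrogen. For the measured compounds named here, the one step that bears on this place, a number 13 percentage points higher from compound 1 to compound 2 (beyond the scatter), shows that taking a group off that carbon raised the maximal response; compound 3 puts a group back onto the same carbon, though a different one, and no measured pair contains the entering group. The expected step is therefore a number 11 percentage points lower from compound 2 to compound 3 (beyond the scatter), modest and downward, with wide uncertainty. Compound 3 is estimated at 88%, between 70% and 105%.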

Compound 3, largest response reached (reported as maximal response), in percent of the reference or control that the assay uses: 0%
Beside the measured number, compound 3's estimate is 88 percentage points above it; measured number below the stated range.
By their numbers in this assay, from the lowest: compound 3; then compound 1; then compound 2.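

In this assay the change to (piperidin-1-yl)methyl is large, with a number 99 percentage points lower from compound 2 to compound 3 (beyond the scatter) and a number 86 percentage points lower from compound 1 to compound 3 (beyond the scatter) as the two readings, against the modest a number 13 percentage points higher from compound 1 to compound 2 (beyond the scatter) that was all the series showed before. This position therefore does more than shade the response: with compound 3 at 0% on this read-out, the group on the saturated chain carbon bound to an aromatic nitrogen can decide whether any maximal response remains at all, and the ethoxycarbonyl result gave no hint of this. Nothing on hand offers an explanation for the collapse.

The compounds shown leave open whether the loss follows the ring nitrogen, the six-membered ring or simply the 2-(piperidin-1-yl)ethyl chain length, as compound 3 carries all three together. A 2-(dimethylamino)ethyl group, a 2-cyclohexylethyl group or a plain propyl chain in place of the 2-(piperidin-1-yl)ethyl would pull these apart, and a 2-hydroxyethyl group would show how the position responds to a small chain with no ring and no amine.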